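Working notes: ethyl on the amide-type nitrogen

A few compounds are considered here, and "the series" means these few. Any claim that something is new, unique, unknown or untested is made for them only; others in the source may bear on it.

Measured so far in a functional assay on EC9706 cells (Homo sapiens) for cytotoxicity, read by MTT assay, with a stated time of 72 h; on this read-out higher numbers stand for weaker inhibition and lower numbers for stronger inhibition:
compound 1 `NC(=O)N1CCN(C(=S)SCc2cn(Cc3ccc(F)cc3)nn2)CC1` gives 62700 nM
compound 2 `CCNC(=O)N1CCN(C(=S)SCc2cn(Cc3ccc(F)cc3)nn2)CC1` gives 27800 nM
compound 3 `Cc1ccc(Cn2cc(CSC(=S)N3CCN(C(N)=O)CC3)nn2)cc1` gives > 128000 nM

Compound 1 and compound 2 share one core and differ in one place, (ethyl in place of hydrogen on an amide-type nitrogen), and that change gives a 2.3-fold lower number from compound 1 to compound 2 (0.35 log units; beyond the scatter). The value of compound 3 is a limit of the assay, not a number. That limit is the limit of > 128000 nM in this assay, at which 1 of the 3 values shown sits.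

Compound 3 differs from compound 1 in its core by methyl in place of fluoro on an aromatic carbon, and that step reads an at least 2.0-fold higher number from compound 1 to compound 3 (0.30 log units; that floor lies within the scatter). Compound 4 `CCNC(=O)N1CCN(C(=S)SCc2cn(Cc3ccc(C)cc3)nn2)CC1` is not yet measured in this assay. It differs from compound 3 by ethyl in place of hydrogen on an amide-type nitrogen. The place of this change is described in the same words as for the pair of compound 1 and compound 2, so it is the same change, made on the core of compound 3 instead of the core of compound 1; among the compounds shown it occurs twice in all.

From compound 3 to compound 4 the step is expected to be about an at least 1.2-fold lower number from compound 3 to compound 4 (0.10 log units; that floor lies within the scatter), beside the earlier one, because the same change gave a 2.3-fold lower number from compound 1 to compound 2 (0.35 log units; beyond the scatter) and nothing among the shown compounds argues for a different size on the second core. Since compound 3 sits at the limit, compound 4 may also return only a limit. The value estimated for compound 4 is 100000 nM, expected to fall between 40000 nM and 300000 nM.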

Compound 4, half-maximal inhibitory concentration: > 128000 nM
Compound 4: a limit, no number; the forecaster's own chance of this, stated with the estimate: 45%; middle value at least 1.2-fold (0.10 log units) away from the limit.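

In this assay compound 4 gives > 128000 nM, which is a limit of the assay and not a number. The step from compound 3 to compound 4 cannot be read, so ethyl in place of hydrogen on the amide-type nitrogen, which gave a 2.3-fold lower number from compound 1 to compound 2 (0.35 log units; beyond the scatter) on the core of compound 1, is neither confirmed nor contradicted on the core of compound 3: the limit of > 128000 nM in this assay, at which 2 of the 4 values shown sit. Methyl in place of fluoro can be read on the ethyl-bearing pair as an at least 4.6-fold higher number from compound 2 to compound 4 (0.66 log units; beyond the scatter), but this does not establish that the change has a different size on the two cores: the same change on two cores in this assay, an at least 2.0-fold higher number (0.30 log units; that floor lies within the scatter) from compound 1 to compound 3 and an at least 4.6-fold higher number (0.66 log units; beyond the scatter) from compound 2 to compound 4; the limit leaves it open whether they differ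

The compounds shown leave open how large the ethyl step is on the core of compound 3 and how far the methyl compounds lie from the fluoro compounds. They also leave open whether a longer chain such as propyl on the amide-type nitrogen, or chloro in place of methyl on the aromatic carbon, would give a number rather than a limit in this assay on that core.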